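The source may report more compounds than this note shows. Statements on the series, on what has been measured and on what is new or still open speak of the compounds shown alone.

Of the compounds shown here, two have been tested so far in a functional assay on HL-60 cells (Homo sapiens) for antiproliferative activity, read by MTT assay, with a stated time of 72 h; a higher number here means a weaker inhibitor, a lower number a stronger inhibitor. Compound 1 (`COc1cc(-c2nc(N(C)C)sc2-c2ccc(C(F)(F)F)cc2)cc(OC)c1OC`) gives > 10000 nM, which is a limit of the assay and not a number. Going by the values given here, compound 2 (`COc1cc(-c2nc(C)sc2-c2ccc(C)cc2)cc(OC)c1OC`) gives 1510 nM, the only actual number available, so it has no measured neighbour to be ranked against. The next compound, compound 3 (`COc1cc(-c2nc(C)sc2-c2ccc(C(F)(F)F)cc2)cc(OC)c1OC`), has trifluoromethyl in place of methyl on an aromatic carbon, para to a large group: trifluoromethyl in place of methyl on an aromatic carbon. Among the compounds with values here, no two measured compounds differ in just one place, so no measured step shows how large this change might be. The expectation therefore starts from compound 2 at 1510 nM and is only tentative. A small weakening, near the edge of the usual scatter, is expected, with an estimated step of a 2.0-fold higher number from compound 2 to compound 3 (0.30 log units; within the scatter). For compound 3 the estimated value in this assay is 3000 nM, with an expected range of 900 nM to 10000 nM.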

Compound 3, half-maximal inhibitory concentration: > 10000 nM
Compound 3: only a limit was reported (the forecaster's own chance of this, stated with the estimate: 20%); middle value at least 3.3-fold (0.52 log units) from the limit.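

In this assay, going by these compounds alone, the change from methyl to trifluoromethyl on the aromatic carbon para to a large group gives the first readable step: an at least 6.6-fold higher number from compound 2 to compound 3 (0.82 log units; beyond the scatter). This shows that the position is not indifferent to the change, since the measurable activity of compound 2 does not survive the swap within the range tested. The value of compound 3 is a limit of the assay and not a number, so the true size of the step stays unknown and only its lower bound is given: the limit of > 10000 nM in this assay, at which 2 of the 3 values shown sit.

The step between compound 1 and compound 3 joins two limits and cannot be read. Going by these compounds, it also remains open whether an amine or a hydroxyl group on this same carbon would keep a measurable value, or whether only methyl does.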